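This account rests on a few compounds, and the source may have more. Where it says the series, first, only, none or still open, it means among the compounds named here.

For the measured compounds named here, compound 2 `C[C@@H](c1ccc(Cl)cc1)N1Cc2cncn2C(CC2(C)COC2)S1(=O)=O` stands highest of the three compounds measured so far in an assay on isolated protein for inhibition of Aromatase (Homo sapiens), tested at 1 uM (a higher number here means more inhibition at the concentration tested (going by the name of the read-out), a lower number less inhibition), where compound 2 gives 35%. Compound 1 `CC(C)CC1n2cncc2CN(CC2CC2)S1(=O)=O` gives 19% in this assay, and compound 3 `CC(C)CC1n2cncc2CN(C2CC2)S1(=O)=O` gives 9%. The distance from compound 2 to compound 1 is beyond the scatter, and so is the distance from compound 2 to compound 3. Going by the values given here, the only step between two measured compounds that differ in a single place is a number 10 percentage points lower from compound 1 to compound 3 (within the scatter), which concerns cyclopropyl in place of cyclopropylmethyl on a sulfonamide nitrogen in a ring.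

Compound 4 `CC(C)OCC1n2cncc2CN([C@@H](C)c2ccc(Cl)cc2)S1(=O)=O` has not yet been measured. It differs from compound 2 in one place: isopropoxy in place of 3-methyloxetan-3-yl on a saturated chain carbon bound to a saturated ring carbon. Among the compounds with values here, no measured step touches that part of the molecule; the step from compound 1 to compound 3 lies at another position and was itself within the scatter, so it gives no direction for the present change. With nothing bearing on it, the account expects no step beyond the scatter in this assay, and the expected step is a number 5 percentage points lower from compound 2 to compound 4 (within the scatter). The estimate for compound 4 in this assay is 30%, with a range from 10% to 50%.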

Compound 4, a percentage reported as inhibition, at one concentration (the size of the read-out at that concentration, not a potency): 23%
Beside the measured number, compound 4's estimate is 7 percentage points above it; the measured number falls inside the stated range.
By their numbers in this assay, from the lowest: compounds 3, 1 and 4 (each within the scatter of the next, the first and the last beyond it); then compound 2.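

In this assay, this position proves responsive: isopropoxy in place of 3-methyloxetan-3-yl on a saturated chain carbon bound to a saturated ring carbon gives a number 12 percentage points lower from compound 2 to compound 4 (beyond the scatter). The only earlier step lay at the sulfonamide nitrogen and stayed within the scatter, so this modest step is the first shown to exceed it, and the higher number belongs to the compound with the 3-methyloxetan-3-yl group. The exchange removes the four-membered ring while the counts of hydrogen-bond donors and acceptors stay the same, but no measurement at hand bears on why the number moves.

On these data alone, a single pair cannot separate the loss of the ring from the other differences between the two groups, so it remains open how a cyclobutyl, a tert-butyl or a methoxymethyl group would read at this place. As far as these compounds go, it also remains open whether the step would hold with cyclopropyl or cyclopropylmethyl on the sulfonamide nitrogen instead of the chlorophenyl-bearing group that compound 2 and compound 4 share.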